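Swapping 3,4-dimethylphenyl for 4-methoxyphenyl in compound 3

The source may report more compounds than this note shows. Statements on the series, on what has been measured and on what is new or still open speak of the compounds shown alone.

Compound 1 `Cn1c(=O)c(=O)n(C2CCCC2)c2nc(N/N=C/c3ccc(O)c(F)c3)ncc21` gives 59300 nM
Compound 2 `Cn1c(=O)c(=O)n(C2CCCC2)c2nc(N/N=C/c3ccc(C(F)(F)F)cc3)ncc21` gives 29000 nM
Compound 3 `Cc1ccc(/C=N/Nc2ncc3c(n2)n(C2CCCC2)c(=O)c(=O)n3C)cc1C` gives 62900 nM

All three values come from a functional assay on HCT-116 cells (Homo sapiens) for antiproliferative activity, read by MTT assay (on this read-out lower numbers stand for stronger inhibition and higher numbers for weaker inhibition), and the compounds differ only in the group on a carbon with a double bond to nitrogen. Compound 3 cannot be told apart from compound 1, since the data show a 1.1-fold higher number from compound 1 to compound 3 (0.03 log units; within the scatter). Compound 2 stands apart from it, with a 2.2-fold higher number from compound 2 to compound 3 (0.34 log units; beyond the scatter).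

Compound 4 `COc1ccc(/C=N/Nc2ncc3c(n2)n(C2CCCC2)c(=O)c(=O)n3C)cc1` has not been measured yet. Its change is 4-methoxyphenyl in place of 3,4-dimethylphenyl on a carbon with a double bond to nitrogen, that is, 4-methoxyphenyl in place of 3,4-dimethylphenyl at that same place. Among the measured compounds shown here, no measured step makes this exact exchange, so the closest guide is the set of exchanges already seen there. Besides the two above, there is a 2.0-fold lower number from compound 1 to compound 2 (0.31 log units; beyond the scatter). Each of these steps is either modest or within the scatter, so three different groups have moved the number only a little. On that evidence, a step beyond the scatter in this assay is not expected, although a slight drop towards the middle of the range is possible. The expected outcome is a 1.4-fold lower number from compound 3 to compound 4 (0.15 log units; within the scatter). For compound 4 the estimated value is 45000 nM, with an expected range from 22000 nM to 90000 nM.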

Compound 4, half-maximal inhibitory concentration: 36100 nM
For compound 4 the middle estimate is 1.2-fold (0.10 log units) above the measured one, and the stated range covers the measured number.
By their numbers in this assay, from the lowest: compounds 2, 4, 1 and 3 (each within the scatter of the next, the first and the last beyond it).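

In this assay, among the compounds shown here, 4-methoxyphenyl has the same heavy-atom count as 3,4-dimethylphenyl and adds one hydrogen-bond acceptor, yet the data show a 1.7-fold lower number from compound 3 to compound 4 (0.24 log units; within the scatter) and thus no step that stands clear of the scatter. Compound 4 also shows a 1.2-fold higher number from compound 2 to compound 4 (0.10 log units; within the scatter) and a 1.6-fold lower number from compound 1 to compound 4 (0.22 log units; within the scatter) and so cannot be separated from any of the other three compounds, although a 2.2-fold higher number from compound 2 to compound 3 (0.34 log units; beyond the scatter) still sets those two apart. Nothing available explains why these four aromatic groups on a carbon with a double bond to nitrogen give such similar numbers.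

All four compounds carry a substituted phenyl ring at this place, so they leave open whether a very different group, such as a carboxylic acid, an amine or a longer chain, would move the number further. They also leave open whether changing the shared core, rather than this group, would give a larger step in this cell assay.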